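A few compounds are considered here, and "the series" means these few. Any claim that something is new, unique, unknown or untested is made for them only; others in the source may bear on it.

Compound 2 `CNC(=O)c1cc(C(=O)NC2CC2)cn(Cc2ccc(F)cc2)c1=O` was measured in a physicochemical assay for solubility; a lower number here means a less soluble compound, a higher number a more soluble compound. For compound 2 the result is a limit of the method rather than a number, >= 162 ug/mL, so its solubility is known only to lie at that boundary or beyond it. The two other compounds measured in this assay also reach only limits. Compound 1 `CNC(=O)c1cc(C(=O)NCCCC2CNCCO2)cn(Cc2ccccc2)c1=O` gives the limit >= 194 ug/mL. Compound 3 `CNC(=O)c1cc(C(=O)NC2CCC2)cn(Cc2cccnc2)c1=O` gives the limit >= 99 ug/mL. No pair among these three differs in only one place, so no single step can be read from them. Compound 4 `CNC(=O)c1cc(C(=O)NC2CC2)cn(Cc2cccc(C#N)c2)c1=O` has not yet been measured; it differs from compound 2 by 3-cyanophenyl in place of 4-fluorophenyl on a saturated chain carbon bound to an aromatic nitrogen. Among the compounds with values here, with no comparable step to lean on, the change from compound 2 to compound 4 is expected to be an at least 1.1-fold lower number from compound 2 to compound 4 (0.06 log units; that floor lies within the scatter), within the usual scatter. Compound 4 is therefore estimated at 140 ug/mL, in a range from 50 ug/mL to 300 ug/mL.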

Compound 4, solubility: >= 148 ug/mL
Compound 4: no number, only a limit (the forecaster's own chance of this, stated with the estimate: 55%); at least 1.0-fold (0.02 log units) between middle value and limit.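

Compound 2 and compound 4 both give only limits in this assay, and the step between them cannot be read. Still open, as far as these compounds go, is where their true values lie, and whether 3-cyanophenyl in place of 4-fluorophenyl changes the result in this assay at all.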